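Ethoxy for methoxy on a nitrile-bearing core

The source may report more compounds than this note shows. Statements on the series, on what has been measured and on what is new or still open speak of the compounds shown alone.

Measured compounds:
compound 1, `CCOc1nc(-c2nc3ccccc3n2C)cc(-c2ccc(Cl)cc2Cl)c1C#N`, 305000 nM
compound 2, `COc1nc(-c2nc3ccccc3n2C)cc(-c2ccc(F)cc2)c1C#N`, 343000 nM

In a functional assay on aorta (Rattus norvegicus, strain Wister) (a higher number here means a weaker inhibitor, a lower number a stronger inhibitor), compound 2 gives 343000 nM, and compound 1 gives 305000 nM; the two numbers lie within the scatter of each other, so neither stands apart. Compound 3, `CCOc1nc(-c2nc3ccccc3n2C)cc(-c2ccc(F)cc2)c1C#N`, differs from compound 2 by methyl in place of hydrogen on a saturated chain carbon bound to an oxygen on an aromatic ring. For the measured compounds named here, no measured pair in this assay isolates that change, so no step beyond the scatter is expected in either direction. The step from compound 2 to compound 3 is therefore estimated as a 1.1-fold lower number from compound 2 to compound 3 (0.06 log units; within the scatter). For compound 3 the expected value in this assay is 300000 nM, within 120000 nM to 750000 nM.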

Compound 3, half-maximal inhibitory concentration: 362000 nM
Beside the measured number, compound 3's estimate is 1.2-fold (0.08 log units) below it; low and high end bracket the measured number.
By their numbers in this assay, from the lowest: compounds 1, 2 and 3 (each within the scatter of the next).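

In this assay, methyl in place of hydrogen on the saturated chain carbon bound to the oxygen, which turns methoxy into ethoxy, gives a 1.1-fold higher number from compound 2 to compound 3 (0.02 log units; within the scatter), so this first measured pair shows the added methyl moving the number no further than the scatter. With ethoxy held fixed, 4-fluorophenyl in place of 2,4-dichlorophenyl gives a 1.2-fold higher number from compound 1 to compound 3 (0.07 log units; within the scatter), which also stays within the scatter. No measurement at hand bears on these results.

On these data alone, whether a longer chain such as propoxy, or an amine in place of the ethoxy, would stand apart from these numbers remains open.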